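Carbamoyl for Bromo on the Silyl-Bound Ring

The compounds below may be only part of what the source reports. "The series", "measured", "known", "first", "only" and "open" are said of these compounds alone.

Compound 1, `CCN(C/C=C/C#CC(C)(C)C)Cc1cccc(OC[Si](C)(C)c2ccc(Cl)cc2)c1`, gives 400 nM in a functional assay on liver (Sus scrofa) for inhibition of squalene monooxygenase (Homo sapiens), using microsomes; a higher number here means a weaker inhibitor, a lower number a stronger inhibitor.
Compound 2, `CCN(C/C=C/C#CC(C)(C)C)Cc1cccc(OC[Si](C)(C)c2ccc(Br)cc2)c1`, gives 210 nM in this assay.
Compound 3, `CCN(C/C=C/C#CC(C)(C)C)Cc1cccc(OC[Si](C)(C)c2ccccc2C(F)(F)F)c1`, gives 70 nM in this assay.

Compound 2 stands second highest of the three numbers in this assay. Its nearest neighbour is compound 1, with a 1.9-fold lower number from compound 1 to compound 2 (0.28 log units; within the scatter), a step that lies within the scatter. Its furthest is compound 3, with a 3.0-fold lower number from compound 2 to compound 3 (0.48 log units; beyond the scatter), a modest step beyond the scatter; compound 1 to compound 3 likewise gave a 5.7-fold lower number from compound 1 to compound 3 (0.76 log units; beyond the scatter).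

Compound 4, `CCN(C/C=C/C#CC(C)(C)C)Cc1cccc(OC[Si](C)(C)c2ccc(C(N)=O)cc2)c1`, differs from compound 2 by carbamoyl in place of bromo on an aromatic carbon. Within the data shown here, none of the measured steps carries this change: the two halogen exchanges and the move to a 2-(trifluoromethyl)phenyl group all leave the ring bearing a halogen or a trifluoromethyl group, whereas compound 4 carries a hydrogen-bond donor and acceptor there. The measured steps show that small changes on this ring shift the number only within the scatter or modestly. The step from compound 2 to compound 4 is therefore expected to be a 3.8-fold higher number from compound 2 to compound 4 (0.58 log units; beyond the scatter), with a wide range in either direction. Compound 4 is estimated at 800 nM in this assay, expected between 200 nM and 4000 nM.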

Compound 4, half-maximal inhibitory concentration: 5000 nM
Compound 4: middle estimate off by 6.3-fold (0.80 log units), on the low side, and the stated range ends below it.
By their numbers in this assay, from the lowest: compound 3; then compounds 2 and 1 (each within the scatter of the next); then compound 4.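

In this assay, this place on the ring, para to a large group, turns out to be far less tolerant than the halogen exchange suggested: where chloro and bromo stayed within the scatter of each other, carbamoyl in place of bromo gives a 24-fold higher number from compound 2 to compound 4 (1.38 log units; beyond the scatter) and carbamoyl in place of chloro gives a 13-fold higher number from compound 1 to compound 4 (1.10 log units; beyond the scatter), both large steps. Against the 2-(trifluoromethyl)phenyl group on silicon, the 4-carbamoylphenyl group gives a 71-fold higher number from compound 3 to compound 4 (1.85 log units; beyond the scatter), the widest gap among the four compounds, so the one entry here with a hydrogen-bond donor on this ring is also clearly the weakest inhibitor of the set. No measurement at hand accounts for the size of this rise.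

The compounds shown leave open whether the loss belongs to the carbamoyl group itself or would also follow other groups at this place, such as a nitrile, a methyl ester, an amine or a carboxylic acid. They also leave open whether an N-methylcarbamoyl group would behave like carbamoyl, and whether a 2-carbamoylphenyl group on silicon would give a number closer to that of the 2-(trifluoromethyl)phenyl compound.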